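Swapping Bromo for Methoxy on a Second Core

This account rests on a few compounds, and the source may have more. Where it says the series, first, only, none or still open, it means among the compounds named here.

Compound 1 `COC(=O)[C@@]1(C)CCC=C2[C@@H]1CC[C@@H](C)[C@]2(C)Cc1c(C)[nH]c2ccc(Br)cc12` and compound 2 `COC(=O)[C@@]1(C)CCC=C2[C@@H]1CC[C@@H](C)[C@]2(C)Cc1c(C)[nH]c2ccc(OC)cc12` share one core and differ only in one group on the indole part. In a functional assay on T47D cells (Homo sapiens) for inhibition, read by sulforhodamine B assay, with a stated time of 48 h (a lower number here means a stronger inhibitor of growth, a higher number a weaker inhibitor of growth), compound 1 gives 16000 nM and compound 2 gives 15000 nM. The change between them is methoxy in place of bromo on an aromatic carbon and it made a 1.1-fold lower number from compound 1 to compound 2 (0.03 log units; within the scatter).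

Compound 3 `COC(=O)[C@@]1(C)CC[C@@H]2C3=C1CC[C@@H](C)[C@]3(C)Cc1c2[nH]c2ccc(Br)cc12` is built on another core; how that core differs from the core of compound 1 is not broken down here. In this assay compound 3 gives 21000 nM. Compound 4 `COC(=O)[C@@]1(C)CC[C@@H]2C3=C1CC[C@@H](C)[C@]3(C)Cc1c2[nH]c2ccc(OC)cc12` is to be measured in this assay and comes from compound 3 by methoxy in place of bromo on an aromatic carbon. Around the place the setting is not identical: in compound 1 the ring carrying the group is part of a fused or bridged system of two rings, in compound 3 of a fused or bridged system of five rings, so this is the same kind of change rather than the same change.

Since the earlier swap made a 1.1-fold lower number from compound 1 to compound 2 (0.03 log units; within the scatter), the step from compound 3 to compound 4 is expected to be a 1.1-fold lower number from compound 3 to compound 4 (0.04 log units; within the scatter). Compound 4 is therefore estimated at 19000 nM, expected between 9000 nM and 40000 nM.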

Compound 4, concentration for 50% growth inhibition: 6500 nM
For compound 4 the middle estimate is 2.9-fold (0.47 log units) above the measured one; measured number outside the range, below it.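

On the core of compound 3, methoxy in place of bromo gave a 3.2-fold lower number from compound 3 to compound 4 (0.51 log units; beyond the scatter) in this assay and so did more there than the same kind of change did on the core of compound 1. In this series, then, the size of a step measured on one core cannot simply be carried over to another core, although two pairs cannot tell which difference between the cores matters or what a third core would do. Set side by side, the two steps do not agree: the same change on two cores in this assay, a 1.1-fold lower number (0.03 log units; within the scatter) from compound 1 to compound 2 and a 3.2-fold lower number (0.51 log units; beyond the scatter) from compound 3 to compound 4, 3.0-fold (0.48 log units) apart, beyond the scatter of two such steps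

The compounds shown carry only bromo or methoxy at this place on the indole part, so it stays open whether another group there, such as chloro or an amine, would also behave differently on the two cores. Going by these compounds, it also stays open how each core would respond to a change elsewhere, for example a carboxylic acid in place of the methyl ester that all four compounds carry.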